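The source may report more compounds than this note shows. Statements on the series, on what has been measured and on what is new or still open speak of the compounds shown alone.

Measured compounds:
Compound 1 `CNC(=O)c1cc(C(=O)NC2CCOCC2)n([C@@H](C)c2ccccc2)n1`: 3.6
Compound 2 `CNC(=O)c1cc(C(=O)N[C@H]2CC[C@H](O)CC2)c([C@@H](C)c2cccc(F)c2)o1`: 4.1
Compound 3 `CNC(=O)c1cc(C(=O)N[C@H]2CC[C@H](O)CC2)c([C@@H](C)c2ccccc2)o1`: 2.8

In a physicochemical assay for lipophilicity (a higher number here means a more lipophilic compound, a lower number a more polar compound), compound 1 stands second highest of the three numbers: compound 2 lies above it, and compound 3 lies below it, both gaps beyond the scatter. The one measured step among these compounds, a number 1.30 log units lower from compound 2 to compound 3 (beyond the scatter), concerns a change on an aromatic carbon and not an amide nitrogen, so it does not bear directly on the change now in question.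

Compound 4 `CNC(=O)c1cc(C(=O)NC)n([C@@H](C)c2ccccc2)n1` differs from compound 1 in a single place: methyl in place of oxan-4-yl on an amide-type nitrogen. A six-membered ring carrying one hydrogen-bond acceptor is exchanged for a one-carbon group carrying none. Within the data shown here, none of the measured steps involves this kind of change, so the expectation rests on the structural difference alone. Replacing oxan-4-yl with methyl removes several carbon atoms along with one oxygen, and a net decrease in this assay is expected, of a size likely beyond the scatter but not as large as the measured step from compound 2 to compound 3.

Compound 4 is therefore expected to give 3 in this assay, within a range from 2.3 to 3.7. The expected step from compound 1 is a number 0.60 log units lower from compound 1 to compound 4 (beyond the scatter).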

Compound 4, distribution coefficient: 3
Estimate against measurement, compound 4: no gap at the digits printed; the measured number falls inside the stated range.
By their numbers in this assay, from the lowest: compounds 3 and 4 (each within the scatter of the next); then compound 1; then compound 2.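

Among these compounds, at the amide-type nitrogen whose other neighbour is the carbonyl carbon, this assay now has its first measured step, and that step is a number 0.60 log units lower from compound 1 to compound 4 (beyond the scatter); the only earlier step concerned an aromatic carbon and said nothing about this position. The result shows that the number in this assay responds to the group on this nitrogen, and that on the core of compound 1 the smaller methyl, with no ring and no hydrogen-bond acceptor, goes with the lower number, so losing the oxygen of oxan-4-yl did not come with a rise. No measured information on the compounds accounts for the size or direction of this step.

This one pair changes the ring, the carbon count and the oxygen all at once, so the compounds shown leave open how much of the step belongs to each, a question that cyclohexyl on the same nitrogen would help to separate. Also open, going by these compounds, is where a longer chain such as propyl, or a ring bearing an amine such as piperidin-4-yl, would fall on this nitrogen.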